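The source may report more compounds than this note shows. Statements on the series, on what has been measured and on what is new or still open speak of the compounds shown alone.

Measured so far in a functional assay on ECa-109 cells (Homo sapiens) for cytotoxicity, read by MTT assay, with a stated time of 48 h; on this read-out higher numbers stand for weaker inhibition and lower numbers for stronger inhibition:
compound 1 `COc1ccc(C(C2=C(O)C(=O)c3ccccc3C2=O)c2c[nH]c3ccccc23)cc1Br`: 11800 nM
compound 2 `O=C1C(O)=C(C(c2cccs2)c2c[nH]c3ccccc23)C(=O)c2ccccc21`: 12100 nM
compound 3 `O=C1C(O)=C(C(c2ccc(Cl)cc2)c2c[nH]c3ccccc23)C(=O)c2ccccc21`: 45800 nM

Compound 3 gives the highest number of the three; its gaps to compound 2 and to compound 1 are each beyond the scatter, whereas compound 1 and compound 2 sit within the scatter of each other.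

Compound 4 `COc1cccc(C(C2=C(O)C(=O)c3ccccc3C2=O)c2c[nH]c3ccccc23)c1` is not yet measured. It differs from compound 3 in one place: 3-methoxyphenyl in place of 4-chlorophenyl on a saturated chain carbon bound to an aromatic carbon and a double-bonded ring carbon.

For the measured compounds named here, two measured steps bear on this change, both arriving at 4-chlorophenyl from another aryl group on the same chain carbon: a 3.9-fold higher number from compound 1 to compound 3 (0.59 log units; beyond the scatter) and a 3.8-fold higher number from compound 2 to compound 3 (0.58 log units; beyond the scatter). The step to compound 4 runs the other way, from 4-chlorophenyl to a methoxy-bearing phenyl; compound 1 likewise carries a methoxy group on its phenyl, together with a bromine. The expectation is therefore a modest step back toward the numbers of compound 1 and compound 2, not a large one. Compound 4 is expected to give 16000 nM in this assay, with a range of 6000 nM to 40000 nM. This estimate corresponds to an expected step of a 2.9-fold lower number from compound 3 to compound 4 (0.46 log units; beyond the scatter).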

Compound 4, half-maximal inhibitory concentration: 40000 nM
Beside the measured number, compound 4's estimate is 2.5-fold (0.40 log units) below it; the range from low to high includes it.
By their numbers in this assay, from the lowest: compounds 1 and 2 (each within the scatter of the next); then compounds 4 and 3 (each within the scatter of the next).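

In this assay, the step of a 1.1-fold lower number from compound 3 to compound 4 (0.06 log units; within the scatter) shows that 3-methoxyphenyl and 4-chlorophenyl cannot be told apart on this chain carbon. The other two steps, a 3.3-fold higher number from compound 2 to compound 4 (0.52 log units; beyond the scatter) and a 3.4-fold higher number from compound 1 to compound 4 (0.53 log units; beyond the scatter), keep thiophen-2-yl and 3-bromo-4-methoxyphenyl clearly on the side of lower numbers. Among these four compounds, the aryl groups therefore fall into two groups, and a methoxy group on the phenyl does not by itself place compound 4 with compound 1, which also carries a bromine.

No measurement at hand explains this split into two groups. Also open, going by these compounds, is where a phenyl bearing a dimethylamino group or a carboxylic acid, or a straight butyl chain on the same carbon, would fall in this assay.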